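Adding a methoxy group to compound 2

The source may report more compounds than this note shows. Statements on the series, on what has been measured and on what is new or still open speak of the compounds shown alone.

Of the compounds shown here, three built on a shared core have been measured in a functional assay on A549/CDDP cells (Homo sapiens) for antiproliferative activity, read by MTT assay, with a stated time of 72 h; on this read-out higher numbers stand for weaker inhibition and lower numbers for stronger inhibition. Compound 1 `Cc1nc(C)c(/C=C/C(=O)/C=C/c2ccccc2O)nc1C` gives 3900 nM, compound 2 `COc1ccccc1/C=C/C(=O)/C=C/c1nc(C)c(C)nc1C` gives 4740 nM, and compound 3 `COc1cccc(/C=C/C(=O)/C=C/c2nc(C)c(C)nc2C)c1` gives 3440 nM. Compound 2 stands level with the other two, since its gaps to both lie within the scatter of repeated measurements, and these numbers do not rank the three.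

Compound 4 `COc1ccc(/C=C/C(=O)/C=C/c2nc(C)c(C)nc2C)c(OC)c1` takes compound 2 and makes one further change: methoxy in place of hydrogen on an aromatic carbon. Put simply, this is methoxy in place of hydrogen on an aromatic carbon. Among the measured compounds shown here, the only measured single change in this set is a 1.2-fold higher number from compound 1 to compound 2 (0.08 log units; within the scatter), which puts methyl in place of hydrogen on an oxygen on an aromatic ring. For the measured compounds named here, that step is small, but it is a different change from the one in compound 4. No measured pair here shows what adding a methoxy group to an aromatic carbon does, so the data offer no reason to expect a shift in either direction. The expected change is therefore none beyond the scatter, and the estimated step is a 1.1-fold lower number from compound 2 to compound 4 (0.05 log units; within the scatter). For compound 4 the estimated value in this assay is 4200 nM, with an expected range from 2000 nM to 8500 nM.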

Compound 4, half-maximal inhibitory concentration: 2850 nM
Estimate against measurement, compound 4: 1.5-fold (0.17 log units) above; low and high end bracket the measured number.
By their numbers in this assay, from the lowest: compounds 4, 3, 1 and 2 (each within the scatter of the next).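

Among the compounds shown here, this is the first step in the set that adds a group to an aromatic carbon, since the only earlier single change sat on an oxygen. In this assay the new methoxy group, meta to a methoxy group and para to a large group, gives a 1.7-fold lower number from compound 2 to compound 4 (0.22 log units; within the scatter) and leaves the two compounds level, so this ring carbon can carry a second methoxy group with no shift that stands out from repeat measurements. No further data are at hand that bear on this result or could say what lies behind it.

One step at one position cannot show whether this tolerance extends to other groups: an amine, a carboxylic acid or a longer chain such as ethoxy on the same aromatic carbon might stay level with compound 2 or move well beyond the scatter. As far as these compounds go, it also remains open whether a methoxy group on this carbon would behave the same way if the other methoxy group were replaced by a hydroxyl group, as a single pair cannot separate the effect of this place from that of its neighbouring groups.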